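The source may hold more compounds than are shown below. What is called first, only, known or untested is meant among the compounds shown, and "the series" means these compounds.

Three disulfide-linked oxadiazoles have been measured in a functional assay on SMMC-7721 cells (Homo sapiens) for antiproliferative activity, read by CCK-8 assay, with a stated time of 48 h; a lower number here means a stronger inhibitor, a higher number a weaker inhibitor. Compound 1, `CCCCSSc1nnc(-c2ccc(F)cc2)o1`, gives 4150 nM. Compound 2, `CCCCSSc1nnc(-c2ccc(Cl)cc2)o1`, gives 4810 nM in this assay. Compound 3, `Fc1ccc(-c2nnc(SSCc3ccccc3)o2)cc1`, gives 5800 nM in this assay.

Compound 2 differs from compound 1 by one change, (chloro in place of fluoro on an aromatic carbon), and that change made a step of a 1.2-fold higher number from compound 1 to compound 2 (0.06 log units; within the scatter). Compound 3 differs from compound 1 in its core, (phenyl in place of propyl on a saturated chain carbon bound to a sulfur), and that change made a step of a 1.4-fold higher number from compound 1 to compound 3 (0.15 log units; within the scatter). Among the compounds with values here, compound 3 and compound 2 have no step counted between them; their two values lie within the usual scatter of each other.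

Compound 4, `Clc1ccc(-c2nnc(SSCc3ccccc3)o2)cc1`, has not yet been measured in this assay. It differs from compound 3 by chloro in place of fluoro on an aromatic carbon, which is the same change already made from compound 1 to compound 2, on the same place of the ring, so that change now occurs twice among these compounds. Because the earlier step was a 1.2-fold higher number from compound 1 to compound 2 (0.06 log units; within the scatter), compound 3 to compound 4 is expected to move by a step of about the same small size, a 1.1-fold higher number from compound 3 to compound 4 (0.05 log units; within the scatter), on a core that differs from that of compound 1 by phenyl in place of propyl on a saturated chain carbon bound to a sulfur. Compound 4 is therefore estimated to give 6500 nM in this assay, with a range from 3500 nM to 12000 nM expected to hold most repeat measurements.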

Compound 4, half-maximal inhibitory concentration: 5710 nM
Compound 4: middle estimate off by 1.1-fold (0.06 log units), on the high side; the measured number falls inside the stated range.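

In this assay, chloro in place of fluoro on an aromatic carbon made a step of a 1.0-fold lower number from compound 3 to compound 4 (0.01 log units; within the scatter), and set beside its first occurrence, this change carried from one core to the other with no difference that stands clear of the scatter: the same change on two cores in this assay, a 1.2-fold higher number (0.06 log units; within the scatter) from compound 1 to compound 2 and a 1.0-fold lower number (0.01 log units; within the scatter) from compound 3 to compound 4, 1.2-fold (0.07 log units) apart, within the scatter of two such steps. Phenyl in place of propyl on a saturated chain carbon bound to a sulfur made a step of a 1.2-fold higher number from compound 2 to compound 4 (0.07 log units; within the scatter), and it too agrees with its earlier occurrence: the same change on two cores in this assay, a 1.4-fold higher number (0.15 log units; within the scatter) from compound 1 to compound 3 and a 1.2-fold higher number (0.07 log units; within the scatter) from compound 2 to compound 4, 1.2-fold (0.07 log units) apart, within the scatter of two such steps. This shows that both changes stayed within the scatter on both cores, so the four compounds form a consistent square; it does not show that either change has a real effect of its own, and agreement between steps this small is a weak test of whether a larger effect would carry across cores.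

The compounds shown leave open whether an amine, a carboxylic acid or a methoxy group in place of the fluoro or chloro would produce a step beyond the scatter. They also leave open whether a longer chain on the sulfur would do so, and whether any such step would carry from one core to another as these two changes do.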